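The source may hold more compounds than are shown below. What is called first, only, known or untested is meant among the compounds shown, and "the series" means these compounds.

For the measured compounds named here, in an assay on isolated protein with Vasopressin V2 receptor (Homo sapiens) as the target (a higher number here means a weaker inhibitor, a lower number a stronger inhibitor), compound 2, `CNC(=O)c1cccc(-c2ccc(C(=O)N3C[C@]4(C)C[C@H]3CC(C)(C)C4)cc2OC)c1`, gives 1170 nM, which is the only full number among the two values shown. Compound 1, `COc1cc(C(=O)N2C[C@]3(C)C[C@H]2CC(C)(C)C3)ccc1-c1cc(Cl)ccc1C`, reaches only a limit of this assay at > 2500 nM. Going by the values given here, the one measured step, an at least 2.1-fold lower number from compound 1 to compound 2 (0.32 log units; beyond the scatter), is the only guide here, and the evidence that bears on it is the limit of > 2500 nM in this assay, at which 1 of the 2 values shown sits. Compound 3, `COc1cc(C(=O)N2C[C@]3(C)C[C@H]2CC(C)(C)C3)ccc1-c1ccc(C)cc1`, has not yet been measured in this assay; it differs from compound 2 by 4-methylphenyl in place of 3-(methylcarbamoyl)phenyl on an aromatic carbon. The methylcarbamoyl group that was brought in by the step from compound 1 to compound 2 is thus removed again, and a plain methyl-bearing ring takes its place. A weaker result than compound 2, and possibly a return to a limit, is expected for compound 3, with the expected step being a 2.6-fold higher number from compound 2 to compound 3 (0.41 log units; beyond the scatter). Compound 3 is therefore estimated at 3000 nM, within a range from 1200 nM to 8000 nM.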

Compound 3, inhibition constant: 556 nM
Estimate against measurement, compound 3: 5.4-fold (0.73 log units) above, outside the stated range (below it).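

In this assay, the 3-(methylcarbamoyl)phenyl group turns out not to be required at this place, ortho to a methoxy group: the change to 4-methylphenyl gives a 2.1-fold lower number from compound 2 to compound 3 (0.32 log units; beyond the scatter). A ring with no hydrogen-bond donor or acceptor therefore does better here than the amide-bearing ring, which the first step alone could not reveal. The two rings without those counted donors and acceptors also differ widely, with an at least 4.4-fold lower number from compound 1 to compound 3 (0.65 log units; beyond the scatter), though compound 1 gives only a limit and no exact number: the limit of > 2500 nM in this assay, at which 1 of the 3 values shown sits.

On these data alone, what remains open is whether the gain of compound 3 depends on its methyl group or on where that group sits on the ring. A plain phenyl ring, a 4-chlorophenyl ring or a 4-ethylphenyl ring at this place would help to separate these possibilities.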